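Chloro to Bromo on the Benzamide Ring of Compound 1

A few compounds are considered here, and "the series" means these few. Any claim that something is new, unique, unknown or untested is made for them only; others in the source may bear on it.

Measured compounds:
- compound 1, `CCN1CCN(c2cc(C)c3cc(NC(=O)c4cccc(Cl)c4)ccc3n2)CC1`: 17800 nM
- compound 2, `Cc1cc(N2CCN(C(C)C)CC2)nc2ccc(NC(=O)c3ccc(Cl)c(Cl)c3)cc12`: 6680 nM

The series is followed in a functional assay on SK-BR-3 cells (Homo sapiens) for antiproliferative activity, read by MTT assay, with a stated time of 72 h; a higher number here means a weaker inhibitor, a lower number a stronger inhibitor. Compound 1 carries the higher of the two numbers shown; in this assay compound 1 gives 17800 nM, while compound 2 gives 6680 nM, a gap that lies beyond the usual scatter. Going by the values given here, no pair of measured compounds differs in only one place, so no single-change step is available as a guide.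

The compound not yet measured is compound 3, `CCN1CCN(c2cc(C)c3cc(NC(=O)c4cccc(Br)c4)ccc3n2)CC1`. It differs from compound 1 in one place: bromo in place of chloro on an aromatic carbon. Nothing in the two measured compounds speaks directly to this exchange. Such a swap of one halogen for another on the same aromatic carbon is expected to move the number little, if at all, so the step of a 1.2-fold lower number from compound 1 to compound 3 (0.07 log units; within the scatter) is expected to stay within the scatter. On that basis compound 3 is estimated at 15000 nM, with a range from 7000 nM to 35000 nM.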

Compound 3, half-maximal inhibitory concentration: 13300 nM
The estimate for compound 3 lay 1.1-fold (0.05 log units) above the measured number, within the range that was stated.
By their numbers in this assay, from the lowest: compounds 2, 3 and 1 (each within the scatter of the next, the first and the last beyond it).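

In this assay, bromo in place of chloro on an aromatic carbon, meta to a large group, gives a 1.3-fold lower number from compound 1 to compound 3 (0.13 log units; within the scatter), so the 3-chlorophenyl and 3-bromophenyl amides cannot be told apart at this level of resolution. Going by these compounds alone, this is the first reading of a change made in one place alone, since the two earlier compounds differ in more than one place and could not isolate this position or this halogen exchange. It shows that, on the background of compound 1, this position accepts the larger halogen without a change in the number that stands beyond the usual scatter, though no measurement shown here bears on the reason for this result.

What the compounds shown leave open is whether a group other than a halogen at this position, such as a methoxy group, an amine or a carboxylic acid, would shift the number beyond the scatter. On these data alone, it also remains open whether fluoro or a trifluoromethyl group there would behave as chloro and bromo do.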